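The compounds below may be only part of what the source reports. "The series", "measured", "known", "first", "only" and "open" are said of these compounds alone.

Three amides on a shared core have so far been run in a physicochemical assay for lipophilicity, read by HPLC; on this read-out lower numbers stand for lower lipophilicity and higher numbers for higher lipophilicity. Compound 1 `O=C(Nc1ccccc1F)c1ccc2cccc(O)c2n1` gives 2.5, compound 2 `O=C(Nc1ccc(F)cc1)c1ccc2cccc(O)c2n1` gives 2.5 and compound 3 `O=C(Nc1cccc(Cl)c1)c1ccc2cccc(O)c2n1` gives 2.5. Compound 2 therefore stands level with compounds 1 and 3 on this read-out. All three steps are flat: no change at the digits printed from compound 1 to compound 2 (within the scatter), no change at the digits printed from compound 1 to compound 3 (within the scatter) and no change at the digits printed from compound 2 to compound 3 (within the scatter), so shifting a fluoro about the phenyl on the amide-type nitrogen, or exchanging fluoro for chloro, left this assay flat across all three.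

Compound 4 `O=C(Nc1ccc(C(F)(F)F)cc1)c1ccc2cccc(O)c2n1` is the next member: trifluoromethyl in place of fluoro on an aromatic carbon. Of the measured steps, no change at the digits printed from compound 2 to compound 3 (within the scatter) is the closest analogy, one halogen exchanged for another on the same phenyl; no change at the digits printed from compound 1 to compound 2 (within the scatter) and no change at the digits printed from compound 1 to compound 3 (within the scatter) are of the same kind and equally flat. None of them brings in a trifluoromethyl, and none replaces one heavy atom by four, so they bound the new case only loosely. The expectation rests on the count of what enters, four heavy atoms for one rather than a like-for-like swap: a rise beyond the scatter is expected, though the flat halogen steps caution against a large one. Compound 4 is accordingly expected to give 3.1 in this assay, within 2.7 to 3.5, an estimated step of a number 0.60 log units higher from compound 2 to compound 4 (beyond the scatter).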

Compound 4, partition coefficient: 2.5
Compound 4: the middle estimate sits 0.60 log units above what was measured; measured number below the stated range.
By their numbers in this assay, from the lowest: compounds 1, 2, 3 and 4 (each within the scatter of the next).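

In this assay, trifluoromethyl in place of fluoro on an aromatic carbon, para to a large group, gives no change at the digits printed from compound 2 to compound 4 (within the scatter), so this position tolerates four heavy atoms entering for one without a shift in the read-out. The earlier steps shown here only moved a halogen about the phenyl or exchanged one halogen for another, whereas this step extends the flat picture to a substituent of a different size, and none of compounds 1, 2, 3 and 4 goes against it. Nothing available bears on why the read-out stays level across this change.

As far as these compounds go, it remains open whether this flat picture holds on the same phenyl for groups of another kind, such as an amine, a carboxylic acid or a longer alkyl chain, since all four compounds carry only halogen or trifluoromethyl there. From the compounds shown here alone, it is also open whether the read-out would respond to a change on the shared core, such as a methoxy group in place of the hydroxyl, as every compound so far keeps that core intact.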